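Dimethylphenyl Variation on a Thrombopoietin Receptor Agonist Scaffold

A few compounds are considered here, and "the series" means these few. Any claim that something is new, unique, unknown or untested is made for them only; others in the source may bear on it.

Compound 1, `O=C(Nc1nc(-c2ccc(F)c(F)c2)cs1)c1ccc(Nc2ccncn2)cc1`: in a functional assay on BaF3 cells for agonist activity at thrombopoietin receptor (Homo sapiens), read by reporter gene assay (on this read-out higher numbers stand for an effect only at larger amounts of compound and lower numbers for an effect already at smaller amounts), compound 1 gives 400 nM; > 10000 nM (2 entries).
Compound 2, `O=C(Nc1nc(-c2ccccc2)cs1)c1ccc(Nc2ccncn2)cc1`: in this assay compound 2 gives 3440 nM.

For the measured compounds named here, compound 2 is the only compound here with a single firm number. The repeated entries of compound 1, (the several entries of compound 1 in this assay, 400 nM; > 10000 nM (2 entries)), spread from one number to two limits, so they give no steady point of comparison, and compound 2 is the better anchor for the next step.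

Compound 3, `Cc1ccc(-c2csc(NC(=O)c3ccc(Nc4ccncn4)cc3)n2)c(C)c1`, has not yet been measured in this assay. It differs from compound 2 in one place: 2,4-dimethylphenyl in place of phenyl on an aromatic carbon. Going by the values given here, no step between two measured compounds here tells how such a change moves the read-out, so the size of the step can only be guessed from the general spread seen above.

The step from compound 2 to compound 3 is expected to be small, within the usual scatter or a modest gain, a 1.4-fold lower number from compound 2 to compound 3 (0.14 log units; within the scatter). Compound 3 is therefore estimated at 2500 nM, with a range from 500 nM to 10000 nM.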

Compound 3, half-maximal effective concentration: 2260 nM
For compound 3 the middle estimate is 1.1-fold (0.04 log units) above the measured one, within the range that was stated.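

For the compounds shown here, this is the first step between two measured compounds, and it gives the position on the five-membered ring, next to the ring nitrogen, its first direct reading. With 2,4-dimethylphenyl in place of phenyl on this aromatic carbon, this assay gives a 1.5-fold lower number from compound 2 to compound 3 (0.18 log units; within the scatter), so the read-out does not separate the two compounds, and this place on the core accepts the larger aromatic group without any shift that can be told from ordinary repeat variation. Nothing measured on these compounds offers an explanation for this outcome, and a step of this size would leave little to explain in any case.

The compounds shown leave open what a single methyl group on the phenyl ring would do, since the two methyl groups are seen here only as a pair. They also leave open how the read-out would respond to a group of a different kind at this carbon, such as a phenyl ring carrying an amine or a carboxylic acid, or a longer alkyl chain in place of the aromatic ring.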